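A Further Methoxy on Compound 2

The source may report more compounds than this note shows. Statements on the series, on what has been measured and on what is new or still open speak of the compounds shown alone.

compound 1 `O=S(=O)(/C=C/c1c(F)c(F)c(F)c(F)c1F)Nc1c(F)c(F)c(F)c(F)c1F` gives 35000 nM
compound 2 `COc1ccc(NS(=O)(=O)/C=C/c2ccccc2OC)cc1` gives 5000 nM
compound 3 `COc1ccc(NS(=O)(=O)/C=C/c2ccc(OC)cc2OC)cc1` gives 15000 nM

In a functional assay on K562 cells (Homo sapiens) for cytotoxicity, read by trypan blue exclusion, with a stated time of 96 h (on this read-out lower numbers stand for stronger inhibition and higher numbers for weaker inhibition), compound 2 gives 5000 nM, the lowest of the three numbers, which makes it the strongest inhibitor of the measured set. The next structure to test is compound 4 `COc1ccc(NS(=O)(=O)/C=C/c2c(OC)cccc2OC)cc1`, which is compound 2 with one change: methoxy in place of hydrogen on an aromatic carbon. The new methoxy sits on an aromatic carbon of a six-membered aromatic ring of carbon only, ortho to a large group and meta to a methoxy group.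

Among the measured compounds shown here, only one measured step bears on this change. It is a 3.0-fold higher number from compound 2 to compound 3 (0.48 log units; beyond the scatter), a modest loss that also came from methoxy in place of hydrogen on an aromatic carbon, though at a different carbon. For the measured compounds named here, no single-place step links compound 1 to the others, so it offers no guide. One step at another carbon is thin evidence, but it points toward weaker inhibition in this assay, and a change of similar modest size seems the fair expectation. The expected step is a 2.0-fold higher number from compound 2 to compound 4 (0.30 log units; within the scatter). For compound 4 the estimated value is 10000 nM, with an expected range from 3500 nM to 30000 nM.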

Compound 4, half-maximal inhibitory concentration: 5000 nM
The estimate for compound 4 lay 2.0-fold (0.30 log units) above the measured number, and the stated range covers the measured number.
By their numbers in this assay, from the lowest: compounds 2 and 4 (each within the scatter of the next); then compound 3; then compound 1.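

In this assay, methoxy in place of hydrogen on the aromatic carbon that is ortho to a large group and meta to a methoxy group brings no change at the digits printed from compound 2 to compound 4 (within the scatter), so this carbon accepts the added group without a measurable cost. The same kind of replacement at a different carbon of that ring brought a 3.0-fold higher number from compound 2 to compound 3 (0.48 log units; beyond the scatter), which shows that the modest loss seen earlier does not follow from adding a methoxy to this ring as such, and that the outcome depends on which carbon receives it. Nothing available here explains why these carbons behave differently.

Methoxy is the only group shown at this carbon, so it remains open whether a hydroxyl, an amine, a chlorine atom or a longer chain such as butoxy would also leave the number unchanged or would shift it in either direction. From the compounds shown here alone, both steps also start from compound 2, so it remains open whether the same replacement would give the same result on a different parent compound.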